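Cyclic amidine in place of open amidine: a second instance

This account rests on a few compounds, and the source may have more. Where it says the series, first, only, none or still open, it means among the compounds named here.

Compound 1 `CC(C)NC(=N)c1ccc2oc(-c3cccc(OCCCCCCOc4ccccc4)c3)cc2c1` gives 7400 nM in an ADME assay on L6 cells (Rattus norvegicus) for cytotoxicity, read by resazurin assay, with a stated time of 70 h; a lower number here means a stronger inhibitor, a higher number a weaker inhibitor. Compound 2 `c1ccc(OCCCCCCOc2cccc(-c3cc4cc(C5=NCCN5)ccc4o3)c2)cc1` carries a group of 5 heavy atoms (3 carbon, 2 nitrogen; one five-membered non-aromatic ring with 2 hetero atoms) in place of a group of 6 heavy atoms (4 carbon, 2 nitrogen; no ring), on an aromatic carbon and gives 2500 nM in this assay, a change of a 3.0-fold lower number from compound 1 to compound 2 (0.47 log units; beyond the scatter). Compound 3 `CC(C)NC(=N)c1ccc2oc(-c3ccc(OCCCCCCOc4ccccc4)cc3)cc2c1` gives 800 nM; the difference between its core and the core of compound 1 is not broken down here. For the measured compounds named here, compound 4 `c1ccc(OCCCCCCOc2ccc(-c3cc4cc(C5=NCCN5)ccc4o3)cc2)cc1` is not yet measured; it carries a group of 5 heavy atoms (3 carbon, 2 nitrogen; one five-membered non-aromatic ring with 2 hetero atoms) in place of a group of 6 heavy atoms (4 carbon, 2 nitrogen; no ring), on an aromatic carbon, the same change as the one between compound 1 and compound 2, at the same place. Compound 4 is expected to show a step of a 3.0-fold lower number from compound 3 to compound 4 (0.47 log units; beyond the scatter), resting on the step seen from compound 1 to compound 2, which was a 3.0-fold lower number from compound 1 to compound 2 (0.47 log units; beyond the scatter). The estimate for compound 4 is therefore 270 nM, between 120 nM and 600 nM.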

Compound 4, half-maximal inhibitory concentration: 1500 nM
Beside the measured number, compound 4's estimate is 5.6-fold (0.74 log units) below it, and the stated range ends below it.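

In this assay, placing the cyclic amidine on the second core in place of the open amidine gives a 1.9-fold higher number from compound 3 to compound 4 (0.27 log units; within the scatter), so on this core the swap separates the two compounds by no more than the usual scatter. The change therefore did not carry over from one core to the other with the same effect: the same change on two cores in this assay, a 3.0-fold lower number (0.47 log units; beyond the scatter) from compound 1 to compound 2 and a 1.9-fold higher number (0.27 log units; within the scatter) from compound 3 to compound 4, 5.6-fold (0.74 log units) apart, beyond the scatter of two such steps This shows that, in these two pairs, the outcome of the swap depends on the core, but it does not show which feature of the cores is responsible, and two pairs give no rule for a further core.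

On these data alone, it remains open how the swap would behave with a longer chain in place of the present one. An amine in place of either amidine also remains untested in the compounds shown here.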